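The source may report more compounds than this note shows. Statements on the series, on what has been measured and on what is new or still open speak of the compounds shown alone.

Measured compounds:
- compound 1, `O=C(NCc1ccc(F)cc1)c1nc(Br)c2cccnc2c1NCCCNc1c(C(=O)NCc2ccc(F)cc2)nc(Br)c2cccnc12`: "not determined" (no result reported)
- compound 2, `CN(C)CCCNc1c(C(=O)NCc2ccc(F)cc2)nc(Br)c2cccnc12`: 7000 nM
- compound 3, `CN(C)c1ccc(CNC(=O)c2nc(Br)c3cccnc3c2N[C@H]2CC[C@H](N)CC2)cc1`: 5000 nM

In a functional assay on MCF7 cells (Homo sapiens) for cytotoxicity, read by MTT assay, with a stated time of 72 h (a higher number here means a weaker inhibitor, a lower number a stronger inhibitor), compound 2 gives 7000 nM, the highest of the two numbers reported. Its nearest neighbour is compound 3, which in this assay gives 5000 nM; the gap between compound 2 and compound 3 is within the scatter, so the two cannot be told apart. Compound 1, the dimeric structure, has no number at all.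

The step to compound 4, `COC(=O)CNc1c(C(=O)NCc2ccc(F)cc2)nc(Br)c2cccnc12`, changes compound 2 in one place: methoxycarbonyl in place of 2-(dimethylamino)ethyl on a saturated chain carbon bound to a nitrogen on an aromatic ring. Within the data shown here, no measured pair shows the effect of this exchange, so the expectation rests on compound 2 alone, whose value 7000 nM sits at the weak end of what has been seen. Without a measured precedent, no strong shift is expected in either direction; a modest loss beyond the scatter is estimated as the more likely outcome, giving a step of a 1.7-fold higher number from compound 2 to compound 4 (0.23 log units; within the scatter). Compound 4 is therefore estimated at 12000 nM, with a range from 3500 nM to 40000 nM.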

Compound 4, half-maximal inhibitory concentration: > 10000 nM
Compound 4: only a limit was reported; the forecaster's own chance of this, stated with the estimate: 25%; the middle value lies beyond the limit too.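

In this assay compound 4 gives > 10000 nM, which is a limit and not a number. Going from 3-(dimethylamino)propyl to (methoxycarbonyl)methyl amounts to an at least 1.4-fold higher number from compound 2 to compound 4 (0.15 log units; that floor lies within the scatter), so this first reading of the change at this position shows no gain from the exchange, while the size of any loss remains undefined. Compound 4 is the only compound shown whose reading ends in this way: the limit of > 10000 nM in this assay, at which 1 of the 4 values shown sits.

Going by these compounds, how far compound 4 lies past its limit remains open, and with it whether the exchange costs anything beyond the scatter. Also open, on these data alone, is how this position would respond to a carboxylic acid, a primary amine or a longer chain ending in a methyl ester in place of the methoxycarbonyl group.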